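Replacing the phenol anilide with a small amide

This account rests on a few compounds, and the source may have more. Where it says the series, first, only, none or still open, it means among the compounds named here.

The series shares one core, on which a carbonyl carries a varying amide partner, and is followed in an assay on isolated protein for inhibition of Apoptosis regulator Bcl-2 (Homo sapiens), read by fluorescence polarization, with stated times of 5 min and 10 min; a lower number here means a stronger inhibitor, a higher number a weaker inhibitor. Compound 1 `CC(C)=CCCC1=CC[C@H](C(=O)Nc2ccc(O)cc2)[C@@H](c2ccccc2)C1` carries a (4-hydroxyphenyl)amino on that carbonyl. In this assay compound 1 gives only a limit, > 23000 nM. Compound 3 `CC(C)=CCCC1=CC[C@@H](C(=O)Nc2ccc(O)cc2)[C@H](c2ccccc2)C1` is its mirror image, and in this assay compound 3 likewise gives only a limit, > 23000 nM. Compound 2 `CC(C)=CCCC1=CC[C@@H](C(=O)Nc2ccc(C(=O)O)cc2)[C@H](c2ccccc2)C1` carries carboxy in place of hydroxy on the aromatic carbon, and in this assay compound 2 gives 2200 nM. Two steps are visible: a step that the two limits leave unreadable from compound 1 to compound 3, and an at least 10-fold higher number from compound 2 to compound 3 (1.01 log units; beyond the scatter). the limit of > 23000 nM in this assay, at which 2 of the 3 values shown sit, places compound 1 at the weak end of the values shown, without a number of its own.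

Compound 4 `CON(C)C(=O)[C@H]1CC=C(CCC=C(C)C)C[C@@H]1c1ccccc1` differs from compound 1 in one place: methoxy(methyl)amino in place of (4-hydroxyphenyl)amino on a carbonyl carbon. Going by the values given here, no measured step removes the aromatic ring from the amide; the step from compound 1 to compound 3 concerns configuration and the step from compound 2 to compound 3 the hydroxy-carboxy exchange, so neither bears directly on it. With compound 1 at a limit, no step beyond the scatter in either direction can be read for compound 4. Compound 4 is expected to remain at the limit, the estimate being 30000 nM within 8000 nM to 100000 nM. This corresponds to an expected step that the limit leaves unreadable from compound 1 to compound 4.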

Compound 4, inhibition constant: 300 nM
The estimate for compound 4 lay 100-fold (2.00 log units) above the measured number; measured number below the stated range.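

In this assay, going by these compounds alone, methoxy(methyl)amino in place of (4-hydroxyphenyl)amino on the carbonyl carbon gives an at least 76-fold lower number from compound 1 to compound 4 (1.88 log units; beyond the scatter), the first step at this position that can be read, and it is large. Among the earlier compounds, only compound 2, with its carboxy, gave a measured number; compound 4 shows that a measured number on the shared core requires neither a carboxy nor an aromatic ring in the amide partner. This step is a bound and not an exact size because compound 1 has only a limit and no number of its own: the limit of > 23000 nM in this assay, at which 2 of the 4 values shown sit.

The compounds shown do not separate the loss of the aromatic ring from the other changes in the amide partner; a dimethylamino, a methoxyamino or a phenylamino on the same carbonyl carbon would each change less at once. How the mirror image of compound 4 would compare also stays open, as the one pair shown that differs only in configuration gives no readable step.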